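From propanoyl to methoxycarbonyl on compound 3

The compounds below may be only part of what the source reports. "The series", "measured", "known", "first", "only" and "open" are said of these compounds alone.

In a toxicity assay on NIH3T3 cells (Mus musculus) for cytotoxicity, read by resazurin assay (a lower number here means that less compound is needed, a higher number that more compound is needed for the effect), compound 3 `CCC(=O)c1ccc(NCc2cncn2Cc2ccc(-c3ccccc3)cc2)cc1-c1ccccc1` stands alongside compound 1 `COC(=O)c1ccc(NCc2cncn2Cc2ccccc2-c2ccccc2)cc1-c1ccccc1` and compound 2 `c1ccc(-c2ccc(Cn3cncc3CNc3ccc(-c4ccccc4)c(-c4ccccc4)c3)cc2)cc1`. For compound 1 the entry is "not determined" (no result reported), so it offers no number. Compound 2 reads > 10000 nM, which is a limit of the assay. Compound 3 reads > 10000 nM, which is also a limit and not a number.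

Compound 4 `COC(=O)c1ccc(NCc2cncn2Cc2ccc(-c3ccccc3)cc2)cc1-c1ccccc1` carries methoxy in place of ethyl on a carbonyl carbon, the change from propanoyl to methoxycarbonyl: methoxy in place of ethyl on a carbonyl carbon. Going by the values given here, the only measured step is a step that the two limits leave unreadable from compound 2 to compound 3, and it gives no size to carry over to this change. The expectation therefore rests on (the limit of > 10000 nM in this assay, at which 2 of the 3 values shown sit), and it is that compound 4 shows no step beyond the scatter and is most likely reported only as a limit again. The estimated step is a step that the limit leaves unreadable from compound 3 to compound 4. Compound 4 is expected at 12000 nM, with an estimated range from 5000 nM to 30000 nM.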

Compound 4, half-maximal effective concentration: > 1000 nM
Compound 4: a limit, no number; the forecaster's own chance of this, stated with the estimate: 85%; the middle value does not contradict the limit.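

Compound 4 reads > 1000 nM, which is a limit and not a number. Compound 3 reads > 10000 nM, also a limit, so neither compound 4's step from compound 3 nor its step from compound 2 can be read. The compounds shown leave open what concentration produces the half-maximal effect in this assay for any of them.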